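Swapping Nitro for Bromo on the Pendant Phenyl Ring

A few compounds are considered here, and "the series" means these few. Any claim that something is new, unique, unknown or untested is made for them only; others in the source may bear on it.

Compound 2 `O=Cc1c(-c2ccc([N+](=O)[O-])cc2)nc2sc(Cc3ccccc3)nn12` is one of three measured compounds that share a core and differ in the groups attached to it. In a functional assay on cells (Cancer cell lines, Homo sapiens) for inhibition (a higher number here means a weaker inhibitor of growth, a lower number a stronger inhibitor of growth), compound 2 gives 39800 nM, the lowest of the three numbers. Compound 1 `COc1ccc(-c2nc3sc(Cc4ccccc4)nn3c2SC#N)cc1` gives 56200 nM, which is within the scatter of compound 2, so the two cannot be told apart. Among the compounds with values here, compound 3 `O=[N+]([O-])c1ccc(-c2nc3sc(Cc4ccccc4)nn3c2Br)cc1` gives 83200 nM, and the only single-change step among the measured compounds, a 2.1-fold higher number from compound 2 to compound 3 (0.32 log units; beyond the scatter), puts bromo in place of formyl on an aromatic carbon of the core.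

Compound 4 `O=Cc1c(-c2ccc(Br)cc2)nc2sc(Cc3ccccc3)nn12` differs from compound 2 by bromo in place of nitro on an aromatic carbon. Within the data shown here, no measured step touches the nitro group on that ring, so nothing directly bears on this change. Among the measured compounds shown here, the one step that involves a bromo group entering, a 2.1-fold higher number from compound 2 to compound 3 (0.32 log units; beyond the scatter), concerns a different place and a different departing group, and it moved the number only modestly. With no closer guide, the change in this assay is expected to be small and could fall either way. Compound 4 is therefore estimated at 50000 nM, with a range from 20000 nM to 125000 nM, a step of a 1.3-fold higher number from compound 2 to compound 4 (0.10 log units; within the scatter) that is expected to stay within the scatter.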

Compound 4, concentration for total growth inhibition: 41700 nM
The estimate for compound 4 lay 1.2-fold (0.08 log units) above the measured number, within the range that was stated.
By their numbers in this assay, from the lowest: compounds 2, 4, 1 and 3 (each within the scatter of the next, the first and the last beyond it).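

Within the data shown here, on the phenyl ring, at the place para to a large group, this is the first direct reading: in this assay, bromo in place of nitro gives a 1.0-fold higher number from compound 2 to compound 4 (0.02 log units; within the scatter). A group of three heavy atoms with two hydrogen-bond acceptors can thus give way to a single bromine atom with no hydrogen-bond acceptors, and the number stays within the scatter, whereas a 2.1-fold higher number from compound 2 to compound 3 (0.32 log units; beyond the scatter) shows a change at a different place, on the core, going beyond the scatter. Nothing measured here gives a reason why the number holds steady across this swap.

From the compounds shown here alone, with only nitro and bromo compared at this place, it remains open whether very different groups there, such as an amine, a carboxylic acid or a longer chain, would also leave the number within the scatter. Going by these compounds, it is also open whether the swap would read the same with something other than formyl on the core, since this single pair carries formyl on both sides.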